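Thiazole series: carbamoyl in place of the aminomethyl chain

A few compounds are considered here, and "the series" means these few. Any claim that something is new, unique, unknown or untested is made for them only; others in the source may bear on it.

Measured so far:
compound 1, `Cc1cccc(Nc2nc(-c3ccncc3)c(CN(C)C)s2)c1`: 16200 nM
compound 2, `Cc1cccc(Nc2nccc(-c3ccncc3)n2)c1`: 6500 nM; 6610 nM (2 entries)
compound 3, `Cc1sc(Nc2ccc3c(c2)CCC3)nc1-c1ccncc1`: 12000 nM

In a functional assay on RCC4 cells (Homo sapiens) for inhibition, read by XTT assay, with a stated time of 4 days (on this read-out lower numbers stand for stronger inhibition and higher numbers for weaker inhibition), compound 1 and compound 3 lie within the usual scatter of each other, so neither is set apart by the two single numbers. Compound 2 has several entries in this assay (the several entries of compound 2 in this assay, 6500 nM; 6610 nM (2 entries)), and they agree closely. Going by the values given here, no two measured compounds differ in one place, so no measured step guides the change to compound 4, `Cc1cccc(Nc2nc(-c3ccncc3)c(C(N)=O)s2)c1`. It differs from compound 1 by carbamoyl in place of (dimethylamino)methyl on an aromatic carbon. For this change the expected step of a 1.4-fold lower number from compound 1 to compound 4 (0.13 log units; within the scatter) is small, in either direction, and not clearly beyond the scatter. Compound 4 is therefore expected at 12000 nM, with a range from 4000 nM to 40000 nM.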

Compound 4, half-maximal inhibitory concentration: 19500 nM
For compound 4 the middle estimate is 1.6-fold (0.21 log units) below the measured one, and the stated range covers the measured number.
By their numbers in this assay, from the lowest: compounds 3, 1 and 4 (each within the scatter of the next).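

In this assay, carbamoyl in place of (dimethylamino)methyl on this aromatic carbon gives a 1.2-fold higher number from compound 1 to compound 4 (0.08 log units; within the scatter), so this read-out does not tell the two groups apart, although the entering group carries a hydrogen-bond donor and the leaving group none. Nothing measured in this series accounts for the result.

Going by these compounds, whether a carboxylic acid, a free aminomethyl group or a longer chain on this carbon would shift the number beyond the scatter stays open. On these data alone, whether carbamoyl behaves alike on the core of compound 3 also stays open.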